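Swapping the Amine Chain on Compound 3

A few compounds are considered here, and "the series" means these few. Any claim that something is new, unique, unknown or untested is made for them only; others in the source may bear on it.

Measured in a functional assay on MDA-MB-231 cells (Homo sapiens) for antiproliferative activity, read by sulforhodamine B assay, with a stated time of 72 h; a higher number here means a weaker inhibitor, a lower number a stronger inhibitor:
- compound 1 `COc1ncc(-c2ccc3ncnc(NCCN(C)C)c3c2)cc1NS(C)(=O)=O`: 2320 nM
- compound 2 `COc1ncc(-c2ccc3ncnc(NCCN(C)C)c3c2)cc1NS(=O)(=O)c1ccc(F)cc1`: 1220 nM
- compound 3 `COc1ncc(-c2ccc3ncnc(NCc4ccncc4)c3c2)cc1NS(=O)(=O)c1ccc(F)cc1F`: 9710 nM

Of these three, compound 3 has the highest number, and its gaps to the other two lie beyond the scatter. Compound 4 `COc1ncc(-c2ccc3ncnc(NCCN(C)C)c3c2)cc1NS(=O)(=O)c1ccc(F)cc1F` has not yet been measured. It arises from compound 3 by one change, (dimethylamino)methyl in place of pyridin-4-yl on a saturated chain carbon bound to a nitrogen on an aromatic ring. Going by the values given here, no measured step isolates this swap. Among the compounds with values here, the only step available, a 1.9-fold lower number from compound 1 to compound 2 (0.28 log units; within the scatter), concerns a sulfonyl substituent, and it suggests that this substituent matters little. The best guide is therefore the shared 2-(dimethylamino)ethyl chain, carried by compound 1 at 2320 nM and compound 2 at 1220 nM. On that basis a large drop in this assay is expected, estimated as an 8.1-fold lower number from compound 3 to compound 4 (0.91 log units; beyond the scatter). Compound 4 is expected at 1200 nM, with an estimated range from 500 nM to 3000 nM.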

Compound 4, half-maximal inhibitory concentration: 710 nM
Beside the measured number, compound 4's estimate is 1.7-fold (0.23 log units) above it; measured number inside the range.
By their numbers in this assay, from the lowest: compounds 4, 2 and 1 (each within the scatter of the next, the first and the last beyond it); then compound 3.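

In this assay the chain on the shared core proves to be the change that counts: with the 2,4-difluorophenyl sulfonyl group held fixed, 2-(dimethylamino)ethyl in place of (pyridin-4-yl)methyl gives a 14-fold lower number from compound 3 to compound 4 (1.14 log units; beyond the scatter) as a large step. The sulfonyl side adds a smaller picture, since the extra fluoro on an aromatic carbon gives a 1.7-fold lower number from compound 2 to compound 4 (0.24 log units; within the scatter) and stays within the scatter, while 2,4-difluorophenyl in place of methyl on the sulfonyl sulfur gives a 3.3-fold lower number from compound 1 to compound 4 (0.51 log units; beyond the scatter) as a modest step beyond it. No measurement is available that would explain either result.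

From the compounds shown here alone, whether a longer chain such as 3-(dimethylamino)propyl, or a morpholine at the chain end, would match the 2-(dimethylamino)ethyl chain remains open. Only compound 3 carries the pyridin-4-yl group, so whether the chain swap would be as large with methyl on the sulfonyl sulfur is also unsettled.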